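A Thioether for an Ether on the Shared Core

The compounds below may be only part of what the source reports. "The series", "measured", "known", "first", "only" and "open" are said of these compounds alone.

Compound 1, `COc1cc(C)nc2n/c(=N/C(=O)c3c(-c4ccc(Cl)cc4Cl)noc3C)sn12`: in a functional assay on the whole organism (strain L.) for inhibition, with Echinochloa crus-galli as the target, with a stated time of 72 h, tested at 10 mg/L (a lower number here means less inhibition of growth, a higher number more inhibition of growth at the concentration tested), compound 1 gives 30.9%.
Compound 2, `COc1cc(OC)n2s/c(=N\C(=O)c3c(-c4ccc(Cl)cc4Cl)noc3C)nc2n1`: compound 2 gives 43.2%.

Among the measured compounds shown here, compound 1 stands lowest of the two numbers, and the single measured step, a number 12.3 percentage points higher from compound 1 to compound 2 (beyond the scatter), is modest though beyond the scatter. Compound 3, `CSc1cc(C)nc2n/c(=N/C(=O)c3c(-c4ccc(Cl)cc4Cl)noc3C)sn12`, differs from compound 1 by methylsulfanyl in place of methoxy on an aromatic carbon. For the measured compounds named here, no measured step covers this exchange; the one step at the same carbon shows that a change at this place moves this assay only modestly. A step of similar or smaller size, in either direction or none beyond the scatter, is therefore expected, a number 4.1 percentage points higher from compound 1 to compound 3 (within the scatter). Compound 3 is expected to give 35%, within 20% to 52%.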

Compound 3, percent growth inhibition at one concentration: 37.5%
Estimate against measurement, compound 3: 2.5 percentage points below, and the stated range covers the measured number.
By their numbers in this assay, from the lowest: compounds 1, 3 and 2 (each within the scatter of the next, the first and the last beyond it).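

Exchanging methoxy for methylsulfanyl on this aromatic carbon gives a number 6.6 percentage points higher from compound 1 to compound 3 (within the scatter) in this assay, so the two groups cannot be told apart here. At this carbon, then, sulfur can stand in place of oxygen in the group without a difference beyond the scatter. Nothing available explains this result.

On these data alone, whether an amine or a longer chain such as ethylsulfanyl on this carbon would move the number remains open. So does whether methylsulfanyl would read the same with methoxy in place of the methyl group on the shared core.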